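The compounds below may be only part of what the source reports. "The series", "measured", "known", "first", "only" and "open" are said of these compounds alone.

Measured compounds:
- compound 1 `O=C(Nc1ccc(Cl)cc1CN1C(=O)c2ccccc2C1=O)C1CCCCC1` — < 1000 nM
- compound 2 `O=C(Nc1ccc(Cl)cc1CN1C(=O)c2ccccc2C1=O)c1ccccc1` — < 1000 nM

In an assay on CHO cells for positive allosteric modulation of metabotropic glutamate receptor 5 (Rattus norvegicus), read by FLIPR (on this read-out higher numbers stand for an effect only at larger amounts of compound and lower numbers for an effect already at smaller amounts), compound 1 gives < 1000 nM, which is a limit of the assay rather than a number. Compound 2 gives < 1000 nM in this assay, and this too is only a limit. The change from cyclohexyl to phenyl on a carbonyl carbon therefore yields a step that the two limits leave unreadable from compound 1 to compound 2, because of the limit of < 1000 nM in this assay, at which 2 of the 2 values shown sit, both values sit at the same limit and the size of the step cannot be read. Compound 2 thus stands only as a limit, with no number to place it against compound 1.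

Compound 3 `O=C(Nc1ccc(Cl)cc1CN1C(=O)c2ccccc2C1=O)c1ncccn1` differs from compound 2 by pyrimidin-2-yl in place of phenyl on a carbonyl carbon. Going by the values given here, no measured step bears on this change in a readable way, so there is no basis for expecting a shift beyond the usual scatter in either direction. The step from compound 2 to compound 3 is therefore expected to be a step that the limit leaves unreadable from compound 2 to compound 3. Compound 3 is estimated to give 600 nM in this assay, within a range from 150 nM to 3000 nM, with a fair chance that only a limit is again reported.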

Compound 3, half-maximal effective concentration: < 1000 nM
Compound 3 ended at the assay's limit; the forecaster's own chance of this, stated with the estimate: 40%; the middle value does not contradict the limit.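

In this assay compound 3 gives < 1000 nM and this is a limit of the assay, not a number. The steps among compound 1, compound 2 and compound 3 therefore cannot be read, because all three share one limit: the limit of < 1000 nM in this assay, at which 3 of the 3 values shown sit. From the compounds shown here alone, how far cyclohexyl, phenyl and pyrimidin-2-yl on the carbonyl carbon differ in effect remains open.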